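Working notes: from pyridin-3-yl to pyridin-4-yl

This account rests on a few compounds, and the source may have more. Where it says the series, first, only, none or still open, it means among the compounds named here.

Measured in a functional assay on K562 cells (Homo sapiens) for inhibition, read by CCK-8 assay, with a stated time of 72 h; on this read-out higher numbers stand for weaker inhibition of growth and lower numbers for stronger inhibition of growth:
- compound 1 `C#Cc1cccc(Nc2ncnc3cc(OC)c(OCCCCCCN/C(=N\C#N)Nc4cccnc4)cc23)c1` gives 0.16 nM
- compound 2 `C#Cc1cccc(Nc2ncnc3cc(OC)c(OCCCCCCCN/C(=N\C#N)Nc4ccncc4)cc23)c1` gives 0.21 nM

On these numbers, compound 1 lies within the scatter of compound 2, so neither stands apart. Compound 3 `C#Cc1cccc(Nc2ncnc3cc(OC)c(OCCCCCCN/C(=N\C#N)Nc4ccncc4)cc23)c1` has pyridin-4-yl in place of pyridin-3-yl on an amine nitrogen, and the change from compound 1 counts as pyridin-4-yl in place of pyridin-3-yl on an amine nitrogen. Among the measured compounds shown here, no measured pair isolates this change. In this assay, no step beyond the scatter is expected, resting only on how closely the two measured compounds agree. The expected step is a 1.3-fold higher number from compound 1 to compound 3 (0.10 log units; within the scatter). Compound 3 is estimated at 0.2 nM, with an expected range of 0.06 nM to 0.7 nM.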

Compound 3, concentration for 50% growth inhibition: 0.15 nM
Compound 3: the middle estimate sits 1.3-fold (0.12 log units) above what was measured; measured number inside the range.
By their numbers in this assay, from the lowest: compounds 3, 1 and 2 (each within the scatter of the next).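

In this assay the swap on the amine nitrogen can now be read directly as a 1.1-fold lower number from compound 1 to compound 3 (0.03 log units; within the scatter) and this step stays within the scatter. On the chain shared by compound 1 and compound 3, pyridin-4-yl and pyridin-3-yl therefore cannot be told apart at this position. Nothing available gives a reason for this result.

Open, on these data alone, is whether pyridin-2-yl or a plain phenyl on the same amine nitrogen would keep values in this range. Also open, as far as these compounds go, is whether pyridin-3-yl and pyridin-4-yl would still match on the longer chain of compound 2.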